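Chloro on the Fluorophenyl Ring: Compound 3 to Compound 4

The compounds below may be only part of what the source reports. "The series", "measured", "known", "first", "only" and "open" are said of these compounds alone.

Three compounds have been measured in a functional assay on U-87MG ATCC cells for antiproliferative activity against U-87 MG (Homo sapiens), read by MTT assay, with a stated time of 72 h; a lower number here means a stronger inhibitor, a higher number a weaker inhibitor:

Compound 1, `CNC(=O)c1cc(Oc2ccc(NC(=O)c3cc4cccnc4n(-c4ccc(F)cc4)c3=O)cc2)ccn1`: 2910 nM
Compound 2, `CCNC(=O)c1cc(Oc2ccc(NC(=O)c3cc4cccnc4n(-c4ccc(F)cc4)c3=O)cc2)ccn1`: 1130 nM
Compound 3, `CCCNC(=O)c1cc(Oc2ccc(NC(=O)c3cc4cccnc4n(-c4ccc(F)cc4)c3=O)cc2)ccn1`: 960 nM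

Compound 3 holds the lowest of the three numbers in this assay, though its gap to compound 2 is within the scatter, and only its gap to compound 1 is clearly beyond it: a 3.0-fold lower number from compound 1 to compound 3 (0.48 log units; beyond the scatter). The measured steps all concern the amide substituent at the far end of the shared core: a 2.6-fold lower number from compound 1 to compound 2 (0.41 log units; beyond the scatter), and a 1.2-fold lower number from compound 2 to compound 3 (0.07 log units; within the scatter).

Compound 4, `CCCNC(=O)c1cc(Oc2ccc(NC(=O)c3cc4cccnc4n(-c4ccc(F)c(Cl)c4)c3=O)cc2)ccn1`, differs from compound 3 elsewhere: chloro in place of hydrogen on an aromatic carbon. Among the measured compounds shown here, none of the measured steps touches that ring, so there is no measured step that bears on this change, and its size and direction cannot be read from the data at hand. The expectation for compound 4 therefore rests on compound 3 alone, and the step is estimated as a 1.2-fold lower number from compound 3 to compound 4 (0.08 log units; within the scatter) in this assay. Compound 4 is accordingly expected to give about 800 nM in this assay, with a wide range from 250 nM to 2500 nM.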

Compound 4, half-maximal inhibitory concentration: 3590 nM
Compound 4: middle estimate off by 4.5-fold (0.65 log units), on the low side; the measured number lies above the stated range.
By their numbers in this assay, from the lowest: compounds 3 and 2 (each within the scatter of the next); then compounds 1 and 4 (each within the scatter of the next).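

Going from 4-fluorophenyl to 3-chloro-4-fluorophenyl is the first change on this ring, and in this assay it gives a 3.7-fold higher number from compound 3 to compound 4 (0.57 log units; beyond the scatter) and so lies beyond the scatter. The aromatic carbon ortho to the fluoro group is therefore not indifferent to a single chloro, and this change raises the number, whereas the earlier amide-chain steps lowered it or stayed within the scatter. No available evidence accounts for this rise.

The compounds shown leave open whether the rise is specific to chloro or would also follow from a methyl, a methoxy or a second fluoro at this place. They also leave open whether adding chloro would shift the number similarly with the shorter amide chains of compound 1 and compound 2.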